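Dimethylamino for anilino on the ring carbon

The compounds below may be only part of what the source reports. "The series", "measured", "known", "first", "only" and "open" are said of these compounds alone.

Compound 3 `OC[C@H]1OC(n2cnc3c(Nc4ccccc4)nccc32)[C@H](O)[C@@H]1O` stands lowest of the two numbers in a functional assay on EL4 cells (Mus musculus) for inhibition, tested at 100 uM (on this read-out lower numbers stand for less inhibition and higher numbers for more inhibition at the one concentration tested (going by the name of the read-out)), where compound 3 gives 10%. Its nearest neighbour, compound 2 `OC[C@H]1OC(n2cnc3c(SCc4ccccc4)nccc32)[C@H](O)[C@@H]1O`, gives 30% in this assay. Compound 1 `CSc1[nH]ccc2ncnc1-2` gives only a limit in this assay, < 5%. Among the compounds with values here, the single measured step, a number 20 percentage points lower from compound 2 to compound 3 (beyond the scatter), concerns a different exchange and bears on the present one only loosely. Compound 4 `CN(C)c1nccc2c1ncn2C1O[C@H](CO)[C@@H](O)[C@H]1O` differs from compound 3 by dimethylamino in place of anilino on an aromatic carbon. No measured step swaps an anilino for a dimethylamino, so the direction is not fixed by the data; compound 3 already sits low, which leaves little room for a fall, and nothing shown points to a rise. Compound 4 is therefore expected to give about 8% in this assay, within 0% to 20%, an expected step of a number 2 percentage points lower from compound 3 to compound 4 (within the scatter) that stays within the scatter.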

Compound 4, a percentage reported as inhibition, at one concentration (the size of the read-out at that concentration, not a potency): 10%
Compound 4: middle estimate off by 2 percentage points, on the low side; the measured number falls inside the stated range.
By their numbers in this assay, from the lowest: compounds 3 and 4 (each within the scatter of the next); then compound 2. At a limit, below all of these: compound 1.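

Exchanging anilino for dimethylamino on the aromatic carbon next to the ring nitrogen removes the aromatic ring and the hydrogen-bond donor, yet gives no change at the digits printed from compound 3 to compound 4 (within the scatter) in this assay, so this level does not depend on either feature. Dimethylamino also matches the anilino result against benzylsulfanyl, with a number 20 percentage points lower from compound 2 to compound 4 (beyond the scatter). Little room may remain beneath these two compounds: the limit of < 5% in this assay, at which 1 of the 4 values shown sits.

On these data alone, it remains open whether the higher number of compound 2 belongs to its sulfur link or its benzyl ring. A benzylamino or benzyloxy group on this carbon would separate the two.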